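This account rests on a few compounds, and the source may have more. Where it says the series, first, only, none or still open, it means among the compounds named here.

Measured compounds:
compound 1 `CC(C)(C)OC(=O)N1Cc2ccc(/C=C/C(=O)NO)cc2C1` — "not determined" (no result reported)
compound 2 `COc1cccc(S(=O)(=O)N2Cc3ccc(/C=C/C(=O)NO)cc3C2)c1` — 1130 nM

In a functional assay on HCT-116 cells (Homo sapiens) for antiproliferative activity (on this read-out lower numbers stand for stronger inhibition and higher numbers for weaker inhibition), compound 1 gives "not determined" (no result reported), so it stands on no single number. Compound 2, `COc1cccc(S(=O)(=O)N2Cc3ccc(/C=C/C(=O)NO)cc3C2)c1`, gives 1130 nM in this assay. Compound 3, `O=C(/C=C/c1ccc2c(c1)CN(Cc1ccccc1)C2)NO`, differs from compound 1 by benzyl in place of tert-butoxycarbonyl on an amine nitrogen in a ring. Going by the values given here, with no value for compound 1 and no measured step on this change, the size of the step in this assay cannot be stated; the shift is expected to be small, likely within scatter, with the potency near that of compound 2. Compound 3 is expected to give about 1500 nM, between 400 nM and 6000 nM.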

Compound 3, half-maximal inhibitory concentration in the HCT-116 assay: 1040 nM
Compound 3: middle estimate off by 1.4-fold (0.16 log units), on the high side; measured number inside the range.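

Going by these compounds alone, compound 1 gives "not determined" (no result reported) in the HCT-116 assay, so no step to compound 3 can be read there. As far as these compounds go, the effect of benzyl in place of tert-butoxycarbonyl on this read-out stays open. In a physicochemical assay for solubility, measured as thermodynamic solubility, at pH 6.8 (on this read-out higher numbers stand for higher solubility and lower numbers for lower solubility), compound 1 gives 99000 nM and compound 3 gives 106000 nM, which is a 1.1-fold higher number from compound 1 to compound 3 (0.03 log units; within the scatter). No evidence bears on this result.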